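The source may report more compounds than this note shows. Statements on the series, on what has been measured and on what is new or still open speak of the compounds shown alone.

Measured compounds:
Compound 1, `C=C1[C@@H](OC(C)=O)C[C@@H]2[C@](C)(CO[Si](C)(C)C(C)(C)C)[C@H](OC(C)=O)CC[C@@]2(C)[C@@H]1C[C@@H](Nc1ccc(OC)cc1)C1=CCOC1=O`, in a functional assay on MCF7 cells (Homo sapiens) for cytotoxicity, read by sulforhodamine B assay; on this read-out higher numbers stand for weaker inhibition and lower numbers for stronger inhibition: 4280 nM
Compound 2, `C=C1[C@@H](OC(C)=O)C[C@@H]2[C@](C)(CO[Si](C)(C)C(C)(C)C)[C@H](OC(C)=O)CC[C@@]2(C)[C@@H]1C[C@@H](Nc1ccc(C(=O)O)cc1)C1=CCOC1=O`: 3990 nM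
Compound 3, `C=C1[C@@H](OC(C)=O)C[C@@H]2[C@](C)(CO[Si](C)(C)C(C)(C)C)[C@H](OC(C)=O)CC[C@@]2(C)[C@@H]1C[C@@H](Nc1cccc2ccccc12)C1=CCOC1=O`: 5770 nM

All three share one core and differ only in the aryl group on the amine nitrogen. Compound 3 gives the highest of the three numbers, but its nearest neighbour is compound 1, at a 1.3-fold higher number from compound 1 to compound 3 (0.13 log units; within the scatter), and its furthest is compound 2, at a 1.4-fold higher number from compound 2 to compound 3 (0.16 log units; within the scatter), so the three compounds cannot be told apart on these numbers.

Compound 4, `C=C1[C@@H](OC(C)=O)C[C@@H]2[C@](C)(CO[Si](C)(C)C(C)(C)C)[C@H](OC(C)=O)CC[C@@]2(C)[C@@H]1C[C@@H](Nc1ccc(OC)c(OC)c1)C1=CCOC1=O`, has not yet been measured. It differs from compound 3 by 3,4-dimethoxyphenyl in place of naphthalen-1-yl on an amine nitrogen. Going by the values given here, the steps that bear on this are those that also exchange the aryl group on the amine nitrogen: a 1.3-fold higher number from compound 1 to compound 3 (0.13 log units; within the scatter) and a 1.4-fold higher number from compound 2 to compound 3 (0.16 log units; within the scatter), both within the scatter, and the exchange of methoxy for carboxy in a 1.1-fold lower number from compound 1 to compound 2 (0.03 log units; within the scatter), also within the scatter. Nothing among these steps points to a change beyond the scatter, so compound 4 is expected to sit close to compound 3, with an estimated step of a 1.3-fold lower number from compound 3 to compound 4 (0.10 log units; within the scatter). Compound 4 is therefore estimated at 4600 nM, within a range of 2500 nM to 8500 nM.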

Compound 4, half-maximal inhibitory concentration: 4310 nM
Compound 4: middle estimate off by 1.1-fold (0.03 log units), on the high side; the range from low to high includes it.
By their numbers in this assay, from the lowest: compounds 2, 1, 4 and 3 (each within the scatter of the next).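

In this assay the group on the amine nitrogen can go from naphthalen-1-yl, with two six-membered aromatic rings of carbon only and no hydrogen-bond acceptors, to 3,4-dimethoxyphenyl, with one such ring and two hydrogen-bond acceptors, and the result is a 1.3-fold lower number from compound 3 to compound 4 (0.13 log units; within the scatter) so even this exchange of ring count and acceptor count leaves the compounds inseparable. A second methoxy in place of hydrogen on an aromatic carbon gives a 1.0-fold higher number from compound 1 to compound 4 (0.00 log units; within the scatter) and 3,4-dimethoxyphenyl in place of 4-carboxyphenyl gives a 1.1-fold higher number from compound 2 to compound 4 (0.03 log units; within the scatter) so all four aryl groups now shown on this nitrogen fall within the scatter of one another, and none of them stands out. No measurement is at hand that would explain this flat result.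

As far as these compounds go, all four compounds carry an aryl group on the nitrogen, so it remains open whether a saturated group such as cyclohexyl, a benzyl group or a pyridyl ring there would give a step beyond the scatter. The shared core stays unchanged throughout, which leaves open what a free hydroxyl in place of the silyl ether or of the acetates would do.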